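The source may report more compounds than this note shows. Statements on the series, on what has been measured and on what is new or still open speak of the compounds shown alone.

Measured so far in this series:
compound 1 `O=S(=O)(NCCCNCc1ccccc1Cl)c1cc(C(F)(F)F)cc(C(F)(F)F)c1` — 13000 nM
compound 2 `O=S(=O)(NCCCNCC1COc2ccccc2O1)c1cc(C(F)(F)F)cc(C(F)(F)F)c1` — 2900 nM
compound 3 `O=S(=O)(NCCCNCc1cccc2ccccc12)c1cc(C(F)(F)F)cc(C(F)(F)F)c1` — 21000 nM

In a functional assay on ASPC1 cells (Homo sapiens) for inhibition, read by MTT assay, with a stated time of 72 h (on this read-out higher numbers stand for weaker inhibition of growth and lower numbers for stronger inhibition of growth), compound 3 gives the highest number of the three; compound 1 sits within the scatter of it, while compound 2 lies well below, as a 7.2-fold higher number from compound 2 to compound 3 (0.86 log units; beyond the scatter) shows. Compound 4 `COc1ccc(CNCCCNS(=O)(=O)c2cc(C(F)(F)F)cc(C(F)(F)F)c2)cc1` differs from compound 3 by 4-methoxyphenyl in place of naphthalen-1-yl on a saturated chain carbon bound to an amine nitrogen. Among the measured compounds shown here, no measured step exchanges exactly these two groups. For the measured compounds named here, the steps that bear on it swap the same position: a 1.6-fold higher number from compound 1 to compound 3 (0.21 log units; within the scatter) stayed within the scatter, whereas a 7.2-fold higher number from compound 2 to compound 3 (0.86 log units; beyond the scatter) went beyond it. With an entering group carrying one acceptor, compound 4 is expected to land between compound 1 and compound 2. The expected step is a 2.3-fold lower number from compound 3 to compound 4 (0.37 log units; beyond the scatter), a modest fall. Compound 4 is estimated at 9000 nM, with a range of 3000 nM to 27000 nM.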

Compound 4, concentration for 50% growth inhibition: 2800 nM
For compound 4 the middle estimate is 3.2-fold (0.51 log units) above the measured one; the measured number lies below the stated range.
By their numbers in this assay, from the lowest: compounds 4 and 2 (each within the scatter of the next); then compounds 1 and 3 (each within the scatter of the next).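

In this assay this position responds strongly to a single-ring group: a 7.5-fold lower number from compound 3 to compound 4 (0.88 log units; beyond the scatter) and a 4.6-fold lower number from compound 1 to compound 4 (0.67 log units; beyond the scatter). With a 1.0-fold lower number from compound 2 to compound 4 (0.02 log units; within the scatter), the four compounds fall into two sets, with the oxygen-bearing groups of compound 2 and compound 4 giving the lower numbers and no counter-example among the four. Nothing available explains this grouping.

As far as these compounds go, whether the oxygen itself matters remains open, since a plain phenyl, 4-hydroxyphenyl or 4-methylphenyl group could fall in either set. From the compounds shown here alone, whether the grouping survives a longer chain is also open.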